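Swapping the Side Group Once More on a Shared Core

This account rests on a few compounds, and the source may have more. Where it says the series, first, only, none or still open, it means among the compounds named here.

Three compounds share one core and differ only in the group on a saturated chain carbon bound to an aromatic carbon and a saturated chain carbon. Compound 1 `CC(C)C(Cc1nnc[nH]1)c1ccc(-c2ccc3cccc(F)c3c2)[nH]c1=O` was tested in an assay on CHO cells for displacement of a labelled ligand from prostaglandin E2 receptor EP3 subtype (Homo sapiens), read by radioligand binding (on this read-out lower numbers stand for stronger inhibition and higher numbers for weaker inhibition), and gives 10 nM. Compound 2 `Cc1nc(C(c2ccc(-c3ccc4cccc(F)c4c3)[nH]c2=O)C(C)C)[nH]c1C` gives 7 nM in this assay, and compound 3 `CC(C)C(c1ccc(-c2ccc3cccc(F)c3c2)[nH]c1=O)N1CCNC1=O` gives 9.1 nM. Of these three numbers compound 1 shows the highest, yet every step stays within the scatter: a 1.4-fold lower number from compound 1 to compound 2 (0.15 log units; within the scatter), a 1.1-fold lower number from compound 1 to compound 3 (0.04 log units; within the scatter) and a 1.3-fold higher number from compound 2 to compound 3 (0.11 log units; within the scatter). So far, then, exchanging this group has not moved the read-out by more than repeated measurements would.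

Compound 4 `CC(C)C(/C=C1\CCNC1=O)c1ccc(-c2ccc3cccc(F)c3c2)[nH]c1=O` carries a further variant at the same place: a group of 7 heavy atoms (5 carbon, 1 nitrogen, 1 oxygen; one five-membered non-aromatic ring with 1 hetero atom) in place of a group of 6 heavy atoms (3 carbon, 3 nitrogen; one five-membered aromatic ring with 3 hetero atoms), on a saturated chain carbon bound to an aromatic carbon and a saturated chain carbon. The group entering here is a non-aromatic ring, whereas the three groups measured so far are all aromatic rings. For the measured compounds named here, the steps that bear on this change are a 1.4-fold lower number from compound 1 to compound 2 (0.15 log units; within the scatter) and a 1.1-fold lower number from compound 1 to compound 3 (0.04 log units; within the scatter), both within the scatter. Following that pattern, the step is expected to be no change at the digits printed from compound 1 to compound 4 (within the scatter), not beyond the scatter. The estimate for compound 4 in this assay is 10 nM, expected to fall between 4 nM and 25 nM.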

Compound 4, inhibition constant: 2.2 nM
Compound 4: middle estimate off by 4.5-fold (0.66 log units), on the high side; measured number below the stated range.
By their numbers in this assay, from the lowest: compound 4; then compounds 2, 3 and 1 (each within the scatter of the next).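

In this assay this position turns out not to be indifferent to the group it carries: the new group gives a 4.5-fold lower number from compound 1 to compound 4 (0.66 log units; beyond the scatter) and a 4.1-fold lower number from compound 3 to compound 4 (0.62 log units; beyond the scatter) and a 3.2-fold lower number from compound 2 to compound 4 (0.50 log units; beyond the scatter) and so each of these modest steps lies beyond the scatter, leaving compound 4 with the lowest number of the four. Having a non-aromatic ring is not enough to explain this pattern, since compound 3 also carries a five-membered non-aromatic ring, yet its number stays within the scatter of those of compound 1 and compound 2. No measurement shown here explains why the group in compound 4 lowers the number.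

The compounds shown leave open whether the lower number goes with the ring itself or with the carbon-carbon double bond that joins it to the shared core, which a version of the same ring attached through a saturated carbon chain would help to separate. They also leave open how an amine, a carboxylic acid or a longer chain would read at this place.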